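One Methyl Fewer on the Dimethoxyphenyl Group

A few compounds are considered here, and "the series" means these few. Any claim that something is new, unique, unknown or untested is made for them only; others in the source may bear on it.

Measured compounds:
Compound 1 `COc1ccc(C=C(C(=O)/C=C/c2cccc(OC)c2OC)C(=O)/C=C/c2cccc(OC)c2OC)cc1OC`: 410 nM
Compound 2 `COc1cc(C=C(C(=O)/C=C/c2cccc(OC)c2OC)C(=O)/C=C/c2cccc(OC)c2OC)cc(OC)c1O`: 420 nM

In a functional assay on SW480 cells (Homo sapiens) for antiproliferative activity, read by sulforhodamine B assay, with a stated time of 48 h (a higher number here means a weaker inhibitor, a lower number a stronger inhibitor), compound 1 gives 410 nM, the lowest of the two numbers shown. Compound 2 gives 420 nM in this assay; the step of a 1.0-fold higher number from compound 1 to compound 2 (0.01 log units; within the scatter) stays within the scatter, so the two compounds cannot be told apart on these numbers.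

Compound 3 `COc1ccc(C=C(C(=O)/C=C/c2cccc(OC)c2OC)C(=O)/C=C/c2cccc(OC)c2OC)cc1O` is compound 1 with a single change:
hydrogen in place of methyl on an oxygen on an aromatic ring

Within the data shown here, only one measured step exists, and it also alters the same ring of compound 1 while leaving the rest of the shared core untouched: a 1.0-fold higher number from compound 1 to compound 2 (0.01 log units; within the scatter). That step changed nothing beyond the scatter. On that basis the step of a 1.1-fold higher number from compound 1 to compound 3 (0.04 log units; within the scatter) is expected to be small as well, with no clear direction beyond the scatter. Compound 3 is therefore estimated at 450 nM in this assay, with a likely range from 200 nM to 1000 nM.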

Compound 3, half-maximal inhibitory concentration: 320 nM
Compound 3: middle estimate off by 1.4-fold (0.15 log units), on the high side, and the stated range covers the measured number.
By their numbers in this assay, from the lowest: compounds 3, 1 and 2 (each within the scatter of the next).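

Taking the methyl off one oxygen, so that 3,4-dimethoxyphenyl becomes 3-hydroxy-4-methoxyphenyl, gives a step within the scatter in this assay: a 1.3-fold lower number from compound 1 to compound 3 (0.11 log units; within the scatter). The comparison with the other hydroxy-bearing ring reads the same way, a 1.3-fold lower number from compound 2 to compound 3 (0.12 log units; within the scatter), so 3-hydroxy-4-methoxyphenyl and 4-hydroxy-3,5-dimethoxyphenyl cannot be told apart here. Directly exchanging methoxy for hydroxy on this ring therefore gives no measurable difference in this assay, and no information is available to explain that result.

As far as these compounds go, it remains open whether an amine or a carboxylic acid in place of this methoxy would move the number beyond the scatter. From the compounds shown here alone, it is also open whether the methoxy groups on the other aromatic rings of the shared core would respond in the same way.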